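Ring-methyl step across two amine substituents

This account rests on a few compounds, and the source may have more. Where it says the series, first, only, none or still open, it means among the compounds named here.

Measured so far:
compound 1 `CC(C(=O)NCc1ccc(C(F)(F)F)nc1NC1CCCCC1)c1ccc(NS(C)(=O)=O)c(F)c1` 20.4 nM
compound 2 `CC1CCC(Nc2nc(C(F)(F)F)ccc2CNC(=O)C(C)c2ccc(NS(C)(=O)=O)c(F)c2)CC1` 27.2 nM
compound 3 `CC(C(=O)NCc1ccc(C(F)(F)F)nc1N1CCN(c2ncccc2Cl)CC1)c1ccc(NS(C)(=O)=O)c(F)c1` 2.1 nM

In a functional assay on CHO-K1 cells for antagonist activity at transient receptor potential cation channel subfamily V member 1 (Homo sapiens), read by FLIPR (a higher number here means a weaker inhibitor, a lower number a stronger inhibitor), compound 1 gives 20.4 nM. Compound 2 differs by methyl in place of hydrogen on a saturated ring carbon and shows a 1.3-fold higher number from compound 1 to compound 2 (0.12 log units; within the scatter). Compound 3 gives 2.1 nM, the lowest of the three numbers; the difference between the core of compound 3 and the core of compound 1 is not broken down here.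

Compound 4 `CC(C(=O)NCc1ccc(C(F)(F)F)nc1N1CCN(c2ncccc2Cl)CC1C)c1ccc(NS(C)(=O)=O)c(F)c1` has not yet been measured in this assay. It differs from compound 3 by methyl in place of hydrogen on a saturated ring carbon. This is the same kind of change as from compound 1 to compound 2, not the same: there the methyl entered a six-membered non-aromatic ring of carbon only, three ring bonds from the ring atom that bears a large group; here it enters a six-membered non-aromatic ring with 2 nitrogen, next to the ring nitrogen and next to the ring atom that bears a large group.

The step from compound 3 to compound 4 is expected to be a 1.4-fold higher number from compound 3 to compound 4 (0.15 log units; within the scatter), because the earlier step of a 1.3-fold higher number from compound 1 to compound 2 (0.12 log units; within the scatter) stayed within the scatter. On that basis compound 4 is estimated at 3 nM, between 1.2 nM and 8 nM.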

Compound 4, inhibition constant: 4.1 nM
Beside the measured number, compound 4's estimate is 1.4-fold (0.14 log units) below it, within the range that was stated.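

In this assay, methyl in place of hydrogen on a saturated ring carbon gives a 2.0-fold higher number from compound 3 to compound 4 (0.29 log units; within the scatter). Set beside the earlier step, the change carries from one core to the other with no step beyond the scatter and no gap between the two steps beyond it: the same change on two cores in this assay, a 1.3-fold higher number (0.12 log units; within the scatter) from compound 1 to compound 2 and a 2.0-fold higher number (0.29 log units; within the scatter) from compound 3 to compound 4, 1.5-fold (0.17 log units) apart, within the scatter of two such steps. This shows only that, in these two pairs, adding the methyl leaves the number within the scatter; it does not show that the step is independent of the core, since the methyl sits in a different ring at a different place in each pair, and two pairs set no rule for the series.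

Still open, from the compounds shown here alone, is whether a group larger than methyl, such as ethyl or hydroxymethyl, on the same saturated ring carbon would also stay within the scatter on either core. Also open, going by these compounds, is how a methyl would behave on the other carbons of the six-membered non-aromatic ring with 2 nitrogen.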